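The compounds below may be only part of what the source reports. "The series", "measured", "known", "first", "only" and "open" are said of these compounds alone.

Measured so far in an assay on isolated protein for inhibition of phosphodiesterase 4A (Sus scrofa); a higher number here means a weaker inhibitor, a lower number a stronger inhibitor: compound 1 `COc1ccc(C(=O)Nc2ccccc2Br)cc1OC1CCCC1` gives 130 nM; compound 2 `COc1ccc(C(=O)Nc2nccs2)cc1OC1CCCC1` gives 6500 nM.

Compound 2 holds the highest number of the two; its nearest neighbour is compound 1, and the gap is a 50-fold higher number from compound 1 to compound 2 (1.70 log units; beyond the scatter), the change being 1,3-thiazol-2-yl in place of 2-bromophenyl on the amide-type nitrogen.

Compound 3 `COc1ccc(C(=O)Nc2c(C)nsc2C#N)cc1OC1CCCC1` is not yet measured. It differs from compound 2 as follows: 5-cyano-3-methyl-1,2-thiazol-4-yl in place of 1,3-thiazol-2-yl on an amide-type nitrogen. For the measured compounds named here, the one step that bears on it is the one from compound 1 to compound 2, a 50-fold higher number from compound 1 to compound 2 (1.70 log units; beyond the scatter), which shows that the group on the amide-type nitrogen moves this assay by a large amount. Compound 3 carries a ring with two flanking substituents, as compound 1 does, so a large move back toward a lower number is expected, of about a 43-fold lower number from compound 2 to compound 3 (1.64 log units; beyond the scatter). For compound 3 the expected value in this assay is 150 nM, with a range from 20 nM to 1500 nM.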

Compound 3, half-maximal inhibitory concentration: 200 nM
Beside the measured number, compound 3's estimate is 1.3-fold (0.12 log units) below it; the range from low to high includes it.
By their numbers in this assay, from the lowest: compounds 1 and 3 (each within the scatter of the next); then compound 2.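

In this assay, a five-membered aromatic ring with 2 hetero atoms on the amide-type nitrogen does not by itself bring the high number of compound 2, since 5-cyano-3-methyl-1,2-thiazol-4-yl in place of 1,3-thiazol-2-yl gives a 33-fold lower number from compound 2 to compound 3 (1.51 log units; beyond the scatter). The 2-bromophenyl group is also not required at this place, as 5-cyano-3-methyl-1,2-thiazol-4-yl in its stead gives a 1.5-fold higher number from compound 1 to compound 3 (0.19 log units; within the scatter), which leaves compounds 1 and 3 level within the scatter. No measurement bearing on the reason for these steps is available.

The step from compound 2 swaps the whole group, so the shares of the nitrile, the methyl and the ring itself remain unseparated. On these data alone, how an amine or a carboxylic acid in place of the nitrile would read in this assay also remains open.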